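A few compounds are considered here, and "the series" means these few. Any claim that something is new, unique, unknown or untested is made for them only; others in the source may bear on it.

Compound 1 `O=C(CCCCC1CCSS1)NO` gives 0.89%
Compound 2 `O=C(CCCCC1CCSS1)Nc1ccccn1` gives "not active" (no number reported)

In a functional assay on KB cells (Homo sapiens) for inhibition, read by MTT assay, with a stated time of 24 h, tested at 10 ug/mL (a higher number here means more inhibition of growth at the concentration tested, a lower number less inhibition of growth), compound 1 reaches 0.89% of growth inhibition, a reading that barely differs from none at all. Compound 2 has no single number to place it, since in this assay compound 2 is reported only as "not active" (no number reported) and so sits at the inactive end of this small set.

Compound 3 `O=C(CCCCC1CCSS1)Nc1ccc(Cl)cn1` keeps the rest of compound 2 and carries chloro in place of hydrogen on an aromatic carbon, two atoms from the ring nitrogen and para to a large group (chloro in place of hydrogen on an aromatic carbon). Within the data shown here, no measured pair shows what such a swap does here. The expectation in this assay is therefore a small upward step at most, probably no larger than the usual scatter. The expected reading for compound 3 is 5% within an estimated range of 0% to 20% and it may also come back without a number.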

Compound 3, percent growth inhibition at one concentration: 28.6%
Compound 3: middle estimate off by 23.6 percentage points, on the low side; the measured number lies above the stated range.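

Among these compounds, compound 2 is reported only as not active, without a number, so no step to compound 3 can be read. No evidence at hand bears on this result. The compounds shown leave open how other groups at that same place on the ring would fare.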